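Aryl piperazine swap on the ring nitrogen, compound 4

The source may report more compounds than this note shows. Statements on the series, on what has been measured and on what is new or still open speak of the compounds shown alone.

Measured so far:
Compound 1 `COc1ccc(N2CCN(Cc3csc(N)c3C(=O)c3ccc(Cl)cc3)CC2)cc1` gives 0% in a functional assay on CHO cells with adenosine receptor A1 (Homo sapiens) as the target, read by cAMP accumulation and immunoassay, with a stated time of 6 min, tested at 0.1 uM; a lower number here means a stronger effect, a higher number a weaker effect of the compound at the concentration tested.
Compound 2 `Nc1scc(CN2CCN(c3ccc(C(F)(F)F)cc3)CC2)c1C(=O)c1cccc(C(F)(F)F)c1` gives -11% in this assay.
Compound 3 `Nc1scc(CN2CCN(c3cccc(F)c3)CC2)c1C(=O)c1cccc(C(F)(F)F)c1` gives -12% in this assay.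

Compound 3 has the lowest number of the three. Compound 2 is nearest; the step of a number 1 percentage points lower from compound 2 to compound 3 (within the scatter) lies within the scatter. Compound 1 is furthest, a gap beyond the scatter.

Compound 4 `Nc1scc(CN2CCN(c3c(F)cccc3F)CC2)c1C(=O)c1cccc(C(F)(F)F)c1` is not yet measured. Change: 2,6-difluorophenyl in place of 3-fluorophenyl on an amine nitrogen in a ring.

Going by the values given here, the only measured step that bears on this change is the exchange of one aryl group for another on the same ring nitrogen, a number 1 percentage points lower from compound 2 to compound 3 (within the scatter), which stayed within the scatter. On that basis the step of a number 2 percentage points higher from compound 3 to compound 4 (within the scatter) is expected to stay within the scatter, in no particular direction. Compound 4 is estimated at -10% in this assay, with a range from -25% to 5%.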

Compound 4, a percentage reported as activity, at one concentration (the size of the read-out at that concentration, not a potency): 1.3%
For compound 4 the middle estimate is 11.3 percentage points below the measured one; the range from low to high includes it.
By their numbers in this assay, from the lowest: compounds 3 and 2 (each within the scatter of the next); then compounds 1 and 4 (each within the scatter of the next).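

In this assay, the aryl group on this ring nitrogen can matter: 2,6-difluorophenyl gives a number 13.3 percentage points higher from compound 3 to compound 4 (beyond the scatter) and a number 12.3 percentage points higher from compound 2 to compound 4 (beyond the scatter), whereas the earlier exchange gave only a number 1 percentage points lower from compound 2 to compound 3 (within the scatter). Going by these compounds alone, the new group thus stands apart from both 3-fluorophenyl and 4-(trifluoromethyl)phenyl, the first aryl exchange here to leave the scatter. Nothing measured here accounts for this shift.

Open, going by these compounds, is whether the step is peculiar to 2,6-difluorophenyl or also appears with a nitrile, a hydroxyl group or an amine on the phenyl ring.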